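Swapping Cyclopropyl for Isopropyl on a Shared Core

This account rests on a few compounds, and the source may have more. Where it says the series, first, only, none or still open, it means among the compounds named here.

Compound 1 `Cn1nc(CN2CCCC2)nc1-c1ccc(C2CC2)cc1` is the only one of the three measured compounds that gives a number in an assay on membranes from Jurkat cells for displacement of a labelled ligand from Sigma intracellular receptor 2 (Homo sapiens), read by scintillation counting, with a stated time of 1 h; on this read-out lower numbers stand for stronger inhibition and higher numbers for weaker inhibition: compound 1 gives 1000 nM. Compound 2 `Cc1cc(-c2nc(CN3CCCC3)nn2C)ccc1C(F)(F)F` reaches only a limit of this assay, > 1000 nM. Compound 3 `Cn1nc(CN2CCCC2)nc1-c1cccc(Oc2ccccc2)c1` likewise shows only a limit, > 1000 nM. Across the set, therefore, there is the limit of > 1000 nM in this assay, at which 2 of the 3 values shown sit. Compound 4 `CC(C)c1ccc(-c2nc(CN3CCCC3)nn2C)cc1` is not yet measured; it differs from compound 1 by isopropyl in place of cyclopropyl on an aromatic carbon. Among the compounds with values here, no measured pair shows what this change does, so in this assay the expected step is none beyond the scatter, which for compound 4 means an expected step of no change at the digits printed from compound 1 to compound 4 (within the scatter). Compound 4 is thus estimated at 1000 nM, with an expected range from 400 nM to 2500 nM.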

Compound 4, inhibition constant: 1000 nM
The estimate for compound 4 equals the measured number at the digits printed, and the stated range covers the measured number.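

Within the data shown here, the pair gives the first reading of a single change at this position: in this assay, isopropyl in place of cyclopropyl on an aromatic carbon, para to a large group, gives no change at the digits printed from compound 1 to compound 4 (within the scatter). Here, then, the three-membered ring of carbon can give way to the open isopropyl group with no shift in the read-out. Both numbers carry the same figure as a limit of the assay: the limit of > 1000 nM in this assay, at which 2 of the 4 values shown sit.

As far as these compounds go, whether an amine, a carboxylic acid or a longer chain at this position would give a lower number stays open. So does whether this swap behaves alike on any other core.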